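Methyl to methoxy on the cinnamic acid ring

The compounds below may be only part of what the source reports. "The series", "measured", "known", "first", "only" and "open" are said of these compounds alone.

Measured compounds:
compound 1 `O=C(O)/C=C/c1ccc(Cn2cccn2)cc1OCCc1ccc2ccccc2c1` 73 nM
compound 2 `Cc1ccc(/C=C/C(=O)O)c(OCCC2(C)CCc3c(C)c(O)c(C)c(C)c3O2)c1` 3100 nM

In an in vitro functional assay on CHO cells for antagonist activity at prostaglandin E2 receptor EP3 subtype (Mus musculus) (on this read-out lower numbers stand for stronger inhibition and higher numbers for weaker inhibition), compound 2 gives 3100 nM, the highest number of the two measured, while compound 1 gives 73 nM, a difference that lies well beyond the scatter. Compound 3 `COc1ccc(/C=C/C(=O)O)c(OCCC2(C)CCc3c(C)c(O)c(C)c(C)c3O2)c1` is the unmeasured neighbour of compound 2. The change is small: methoxy in place of methyl on an aromatic carbon. Among the measured compounds shown here, no measured pair shows what this particular swap does on this core, so the expectation rests on the modest size of the change and on the starting value of compound 2. A step of this kind is expected to stay within the scatter in this assay, with no clear direction. The estimated step from compound 2 to compound 3 is a 1.2-fold lower number from compound 2 to compound 3 (0.09 log units; within the scatter). For compound 3 the expected value in this assay is 2500 nM, with a range from 800 nM to 8000 nM.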

Compound 3, half-maximal inhibitory concentration: > 10000 nM
Compound 3 was reported as a limit; the forecaster's own chance of this, stated with the estimate: 10%; at least 4.0-fold (0.60 log units) between middle value and limit.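

In this assay, among the compounds shown here, methoxy in place of methyl on this aromatic carbon, para to a 2-carboxyethenyl group, gives an at least 3.2-fold higher number from compound 2 to compound 3 (0.50 log units; beyond the scatter), the first step in this set and one showing that even a small swap at this position can clearly weaken inhibition. Compound 3 gives > 10000 nM, which is a limit of the assay and not a number. The step therefore sets only a minimum size, and the true loss remains unknown because compound 3 sits at that limit: the limit of > 10000 nM in this assay, at which 1 of the 3 values shown sits.

The compounds shown leave open how a hydroxyl group, a chlorine atom or an ethyl group on this same carbon would compare with methyl. They also leave open whether methoxy would have a similar effect on the core of compound 1.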